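A few compounds are considered here, and "the series" means these few. Any claim that something is new, unique, unknown or untested is made for them only; others in the source may bear on it.

Compound 3 `CC(C)[C@H](NC(=O)COc1cccc2ccccc12)C(=O)N[C@@H](CC(=O)O)C(=O)COc1ccncn1` stands at a limit in a functional assay on Jurkat cells (Homo sapiens) for inhibition; on this read-out higher numbers stand for weaker inhibition and lower numbers for stronger inhibition: compound 3 gives > 200000 nM, which is a limit of the assay and not a number. Compound 1 `CC(C)c1cc(OCC(=O)[C@H](CC(=O)O)NC(=O)[C@@H](NC(=O)COc2cccc3ccccc23)C(C)C)no1` likewise returns a limit, > 200000 nM. Among the compounds with values here, compound 2 `CC(C)[C@H](NC(=O)COc1cccc2ccccc12)C(=O)N[C@@H](CC(=O)O)C(=O)CSc1nnc(-c2ccccc2)o1` carries the only numbered value, 150000 nM. The steps among them read an at least 1.3-fold lower number from compound 1 to compound 2 (0.12 log units; that floor lies within the scatter), an at least 1.3-fold higher number from compound 2 to compound 3 (0.12 log units; that floor lies within the scatter) and a step that the two limits leave unreadable from compound 1 to compound 3, with two of the three values resting at the limit of > 200000 nM in this assay, at which 2 of the 3 values shown sit. Compound 4 `CC(C)[C@H](NC(=O)COc1cccc2ccccc12)C(=O)N[C@@H](CC(=O)O)C(=O)COc1nccc(C(F)(F)F)n1` differs from compound 3 by 4-(trifluoromethyl)pyrimidin-2-yl in place of pyrimidin-4-yl on an oxygen on a saturated carbon. Within the data shown here, no measured step bears directly on this change; each swaps the whole group on the oxygen, and all land at or near the limit, so no step beyond the scatter is expected in this assay. Compound 4 is therefore estimated at 200000 nM (range 50000 nM to 800000 nM). The expected step of a number no higher from compound 3 to compound 4 (the limit leaves the size open) most likely ends again as a limit.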

Compound 4, half-maximal inhibitory concentration: > 200000 nM
Compound 4: no number, only a limit (the forecaster's own chance of this, stated with the estimate: 70%); the middle value sits exactly at the limit.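

In this assay compound 4 gives > 200000 nM, which is a limit of the assay and not a number. Within the data shown here, the steps to compound 4 from compound 3 and from compound 1 cannot be read, and the only readable step is an at least 1.3-fold higher number from compound 2 to compound 4 (0.12 log units; that floor lies within the scatter). Placing 4-(trifluoromethyl)pyrimidin-2-yl on the oxygen therefore leaves the series at its ceiling: the limit of > 200000 nM in this assay, at which 3 of the 4 values shown sit.

Still open, from the compounds shown here alone, is how the read-out responds when an amine or a longer alkyl chain replaces the aromatic ring on this oxygen. Also open, going by these compounds, is whether the sulfanyl link or the 5-phenyl-1,3,4-oxadiazol-2-yl ring accounts for the numbered value of compound 2.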